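The compounds below may be only part of what the source reports. "The series", "measured", "known", "first", "only" and "open" are said of these compounds alone.

Measured in an ADME assay on microsomes from liver (Mus musculus) for metabolic stability, read by LC-MS, with a stated time of 30 min, tested at 1 uM; a lower number here means that less of the compound is left, a higher number that more of the compound is left:
Compound 1 `O=C(NCc1ccc(S(=O)(=O)c2ccccc2)cc1)c1ccc2ncncc2c1`: 3.7%
Compound 2 `O=C(NCc1ccc(S(=O)(=O)c2ccccc2)cc1)c1nc2cnccc2[nH]1`: 7.3%

Among the compounds with values here, only two compounds have been measured so far, and little of either survives the test. Compound 2 gives 7.3% and compound 1 gives 3.7%. These two values lie within the usual scatter of each other, so this assay does not separate them.

The next compound to be tested is compound 3 `O=C(NCc1ccc(S(=O)(=O)c2ccccc2)cc1)c1cc2ccncc2s1`. Its structural change from compound 2 is a group of 9 heavy atoms (7 carbon, 1 nitrogen, 1 sulfur; one five-membered aromatic ring with 1 hetero atom, one six-membered aromatic ring with 1 hetero atom) in place of a group of 9 heavy atoms (6 carbon, 3 nitrogen; one five-membered aromatic ring with 2 hetero atoms, one six-membered aromatic ring with 1 hetero atom), on a carbonyl carbon. The swap takes place on a carbonyl carbon, and the rest of the structure stays the same.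

Within the data shown here, no measured pair of compounds differs in one place only, so the data give no direct guide to the size of this swap. The expectation rests only on the low values of compound 1 at 3.7% and compound 2 at 7.3%. The expected change is a number 1.3 percentage points lower from compound 2 to compound 3 (within the scatter), an estimated step with no clear direction and none beyond the scatter. For compound 3 the estimated value is 6%, with an expected range of 1% to 20%.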

Compound 3, percent of the compound remaining: 21%
Compound 3: middle estimate off by 15 percentage points, on the low side; measured number outside the range, above it.
By their numbers in this assay, from the lowest: compounds 1 and 2 (each within the scatter of the next); then compound 3.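

In this assay, within the data shown here, the group on the carbonyl carbon clearly matters: the swap gives a number 13.7 percentage points higher from compound 2 to compound 3 (beyond the scatter), the only step in this set and one that lies beyond the scatter. Both groups have the same number of heavy atoms and the same pair of ring sizes, but the entering group has 7 carbon, 1 nitrogen and 1 sulfur where the leaving group has 6 carbon and 3 nitrogen, and it has 0 hydrogen-bond donors where the leaving group has 1. No measurement here links the step to any one of these differences or to any property of the groups, so its cause remains unknown.

Even so, compound 3 keeps only 21%, so most of it is still lost during the test, and a single step cannot show how much further a change at this position could go. Going by these compounds, it also remains open whether a simpler group on the carbonyl carbon, such as a plain thiophene or pyridine ring, would match this step, or whether a fluorine on the entering group would add to it.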